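The source may hold more compounds than are shown below. What is called first, only, known or untested is meant among the compounds shown, and "the series" means these compounds.

Working notes on the series. Within the data shown here, in a functional assay on SNB-75 cells (Homo sapiens) for inhibition, read by sulforhodamine B assay, with a stated time of 48 h (on this read-out lower numbers stand for stronger inhibition of growth and higher numbers for weaker inhibition of growth), compound 1 `O=C(Cc1csc2nc(-c3ccc(Br)cc3)cn12)N/N=C/c1ccccc1` gives 89100 nM, the higher of the only two numbers available. Compound 2 `O=C(Cc1csc2nc(-c3ccc(Br)cc3)cn12)N/N=C/c1ccccc1O` gives 32400 nM in this assay.

The next analogue, compound 3 `O=C(Cc1csc2nc(-c3ccc(Br)cc3)cn12)N/N=C/c1ccc(Cl)cc1Cl`, carries 2,4-dichlorophenyl in place of phenyl on a carbon with a double bond to nitrogen.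

Among the measured compounds shown here, one measured step bears on this change, and only indirectly. Hydroxy in place of hydrogen on an aromatic carbon gave a 2.8-fold lower number from compound 1 to compound 2 (0.44 log units; beyond the scatter), a modest move toward a lower number. For the measured compounds named here, that step changes the same aromatic ring that is replaced in compound 3, but it installs a different substituent, and no chlorinated compound has been measured. The size of the step from compound 2 therefore serves only as a rough guide, and a modest move toward a lower number in this assay is expected, with considerable uncertainty.

The expected change is a 2.2-fold lower number from compound 1 to compound 3 (0.35 log units; beyond the scatter). For compound 3 the estimated value is 40000 nM, with an expected range of 15000 nM to 100000 nM.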

Compound 3, concentration for total growth inhibition: > 100000 nM
Compound 3: a limit, no number; the forecaster's own chance of this, stated with the estimate: 20%; at least 2.5-fold (0.39 log units) between middle value and limit.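

In this assay compound 3 gives a limit of the assay, not a number: the limit of > 100000 nM in this assay, at which 1 of the 3 values shown sits. Measured against the unsubstituted phenyl, the change to 2,4-dichlorophenyl on a carbon with a double bond to nitrogen gives an at least 1.1-fold higher number from compound 1 to compound 3 (0.05 log units; that floor lies within the scatter), so these two compounds cannot be placed in any order, and this substitution shows no sign of the lower number seen with the hydroxy change. Measured against the other substituted ring, the change gives an at least 3.0-fold higher number from compound 2 to compound 3 (0.48 log units; beyond the scatter), which shows that the lower number of compound 2 does not follow from any substitution of this ring, since 2,4-dichlorophenyl does not retain it.

The compounds shown leave open whether the lower number of compound 2 depends on the hydroxy group itself, or whether a methoxy group or an amine on the same ring would give a similar number. They also leave open whether a ring with a single chlorine would behave like compound 3 or like compound 1, and how far compound 3 actually lies from either.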